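The compounds below may be only part of what the source reports. "The series", "measured", "known", "first", "only" and "open" are said of these compounds alone.

Measured so far:
compound 1 `O=C(Nc1cccc(-n2cc(-c3ccncc3)c(-c3ccc(Cl)c(O)c3)n2)c1)Nc1cccc(C(F)(F)F)c1` — 2470 nM
compound 2 `COc1cc(-c2nn(-c3cccc(NC(=O)Nc4cc(C(F)(F)F)cc(C(F)(F)F)c4)c3)cc2-c2ccncc2)ccc1Cl` — 1550 nM
compound 3 `COc1cc(-c2nn(-c3cccc(NC(=O)Nc4cccc(C(F)(F)F)c4)c3)cc2-c2ccncc2)ccc1Cl` — 1650 nM

In a functional assay on T47D cells (Homo sapiens) for inhibition, read by sulforhodamine B assay, with a stated time of 48 h (on this read-out lower numbers stand for stronger inhibition of growth and higher numbers for weaker inhibition of growth), compound 2 gives the smallest number of the three, yet its gaps to compound 3 and to compound 1 both sit within the scatter, so no order among them is secure. Compound 4 `O=C(Nc1cccc(-n2cc(-c3ccncc3)c(-c3ccc(Cl)c(O)c3)n2)c1)Nc1cc(C(F)(F)F)cc(C(F)(F)F)c1` is reached from compound 2 by hydrogen in place of methyl on an oxygen on an aromatic ring. For the measured compounds named here, the only measured step bearing on this change is its reverse, a 1.5-fold lower number from compound 1 to compound 3 (0.18 log units; within the scatter), itself within the scatter. Run the other way, it gives no ground to expect more than a small shift toward a higher number in this assay for compound 4, if any. Compound 4 is estimated at 2300 nM (range 1000 nM to 5000 nM), an expected step of a 1.5-fold higher number from compound 2 to compound 4 (0.17 log units; within the scatter).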

Compound 4, concentration for 50% growth inhibition: 1820 nM
The estimate for compound 4 lay 1.3-fold (0.10 log units) above the measured number; measured number inside the range.
By their numbers in this assay, from the lowest: compounds 2, 3, 4 and 1 (each within the scatter of the next).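

In this assay, the change from methoxy to hydroxy now has a reading on a second core, a 1.2-fold higher number from compound 2 to compound 4 (0.07 log units; within the scatter), and the two readings agree: the same change on two cores in this assay, a 1.5-fold lower number (0.18 log units; within the scatter) from compound 1 to compound 3 and a 1.2-fold lower number (0.07 log units; within the scatter) from compound 4 to compound 2, 1.3-fold (0.11 log units) apart, within the scatter of two such steps. Trifluoromethyl in place of hydrogen on an aromatic carbon also gains a second reading, a 1.4-fold lower number from compound 1 to compound 4 (0.13 log units; within the scatter), again in agreement with the first: the same change on two cores in this assay, a 1.1-fold higher number (0.03 log units; within the scatter) from compound 2 to compound 3 and a 1.4-fold higher number (0.13 log units; within the scatter) from compound 4 to compound 1, 1.3-fold (0.11 log units) apart, within the scatter of two such steps. Neither change moves the number beyond the scatter on these cores. Still open, on these data alone, is whether a longer chain such as ethoxy, or an amine in place of hydroxy, would shift the number beyond the scatter.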